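Ether chain variation on the shared core: compound 3 to compound 4

The compounds below may be only part of what the source reports. "The series", "measured", "known", "first", "only" and "open" are said of these compounds alone.

The series varies the ether chain on a shared core. Compound 1 `CC(C)COc1ccc2c(Cl)ccnc2c1` is measured in a functional assay on SK-OV-3 cells (Homo sapiens) for cytotoxicity, read by MTT assay, with a stated time of 48 h (a higher number here means a weaker inhibitor, a lower number a stronger inhibitor), and gives 3190 nM. Compound 2 `CCCCOc1ccc2c(Cl)ccnc2c1` gives 4130 nM in this assay; the step of a 1.3-fold higher number from compound 1 to compound 2 (0.11 log units; within the scatter) is within the scatter. Compound 3 `CCCCCCOc1ccc2c(Cl)ccnc2c1` is reported in this assay only as a limit, > 10000 nM, so no number is known for it (the limit of > 10000 nM in this assay, at which 1 of the 3 values shown sits). Against compound 1 the step of an at least 3.1-fold higher number from compound 1 to compound 3 (0.49 log units; beyond the scatter) runs toward a higher number, and against compound 2 the step of an at least 2.4-fold higher number from compound 2 to compound 3 (0.38 log units; beyond the scatter) runs the same way; both are beyond the scatter. Compound 4 `Clc1ccnc2cc(OCCCc3ccccc3)ccc12` is not yet measured in this assay. Its change from compound 3 is phenyl in place of propyl on a saturated chain carbon, three bonds along the chain from an oxygen on an aromatic ring. Going by the values given here, no measured step here replaces part of a chain with an aromatic ring, so the measured steps bear only loosely on it; what they show is that the longer chain of compound 3 gave a higher number than compound 1 or compound 2. Compound 4 carries a chain of comparable reach, so it is expected to stay near the limit region, and the step of an at least 1.1-fold lower number from compound 3 to compound 4 (0.04 log units; that floor lies within the scatter) is expected to be small. The estimate for compound 4 is 9000 nM, ranging from 3000 nM to 30000 nM.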

Compound 4, half-maximal inhibitory concentration: 3610 nM
Compound 4: the middle estimate sits 2.5-fold (0.40 log units) above what was measured; the measured number falls inside the stated range.
By their numbers in this assay, from the lowest: compounds 1, 4 and 2 (each within the scatter of the next). At a limit, above all of these: compound 3.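

At this position, on a saturated chain carbon three bonds along the chain from an oxygen on an aromatic ring, phenyl in place of propyl gives an at least 2.7-fold lower number from compound 3 to compound 4 (0.44 log units; beyond the scatter) in this assay, so a long ether chain on the shared core does not by itself go with a high number, and compound 4 goes against the trend that compound 1, compound 2 and compound 3 seemed to suggest. From the compounds shown here alone, compound 3 is reported only as a limit, so that step is a floor and its true size stays unknown: the limit of > 10000 nM in this assay, at which 1 of the 4 values shown sits. Against the shorter butyl-type ether of compound 2, phenyl in place of methyl gives a 1.1-fold lower number from compound 2 to compound 4 (0.06 log units; within the scatter), so the terminal phenyl keeps compound 4 level with compound 2 in this assay despite the added ring.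

The compounds shown leave open how the result depends on the distance from the ether oxygen to the phenyl, as a benzyl ether or a longer chain ending in phenyl would test. They also leave open whether an amine, a carboxylic acid or a substituted phenyl at the chain end would hold the number at this level.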